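Working notes: from compound 2 to compound 4

The compounds below may be only part of what the source reports. "The series", "measured", "known", "first", "only" and "open" are said of these compounds alone.

Compound 2 `O=C1OC(Cc2nc(-c3ccccc3)no2)c2ccccc21` gives > 10000 nM in a functional assay on RAW264.7 cells (Mus musculus) for inhibition, read by Griess assay, with stated times of 1 h and 24 h (on this read-out higher numbers stand for weaker inhibition and lower numbers for stronger inhibition), which is a limit and not a number. Compound 1 `Cc1noc(CC2OC(=O)c3ccccc32)n1` gives > 10000 nM, also a limit. Compound 3 `O=C1OC(Cc2nc(Cc3ccccc3)no2)c2ccccc21` gives > 10000 nM, again a limit. The standing of compound 2 therefore cannot be ranked against either neighbour, and the whole set rests at the limit of > 10000 nM in this assay, at which 3 of the 3 values shown sit.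

Compound 4 `O=C1OC(Cc2nc(-c3ccc(Oc4ccccc4)cc3)no2)c2ccccc21` differs from compound 2 by phenoxy in place of hydrogen on an aromatic carbon. The change is phenoxy in place of hydrogen on an aromatic carbon, para to a large group.

Going by the values given here, three measured steps bear on this change only loosely. They are a step that the two limits leave unreadable from compound 1 to compound 2, a step that the two limits leave unreadable from compound 1 to compound 3 and a step that the two limits leave unreadable from compound 2 to compound 3. None has a readable size, and none involves phenoxy. No gain or loss in this assay can be carried over from them due to the limit of > 10000 nM in this assay, at which 3 of the 3 values shown sit.

Among the compounds with values here, with no measured step to support a shift in either direction, the expectation is that compound 4 stays near the limit. The expected a number no higher from compound 2 to compound 4 (the limit leaves the size open) is therefore only a working figure. For compound 4 the estimated value is 10000 nM, with an expected range of 3000 nM to 30000 nM.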

Compound 4, half-maximal inhibitory concentration: > 10000 nM
Compound 4: a limit, no number (the forecaster's own chance of this, stated with the estimate: 65%); the middle value lies on the limit itself.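

Compound 4 gives > 10000 nM in this assay as a limit and not a number, so the phenoxy change from compound 2 to compound 4 yields no readable step: the limit of > 10000 nM in this assay, at which 4 of the 4 values shown sit. The compounds shown leave open whether any member of this series reaches a readable value in this assay and which change would bring that about.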